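The compounds below may be only part of what the source reports. "The series", "measured", "known", "first", "only" and "open" are said of these compounds alone.

Measured compounds:
- compound 1, `CCCC1=C(C(=O)OCC)C(c2cccc([N+](=O)[O-])c2)C(C(=O)OCC)=C(C)N1`, gives 18 nM in a functional assay on HEK293 cells for antagonist activity at Voltage-dependent L-type calcium channel subunit alpha-1C (Oryctolagus cuniculus), read by FLIPR; a lower number here means a stronger inhibitor, a higher number a weaker inhibitor
- compound 2, `C=CCOC(=O)C1=C(C)NC(C)=C(C(=O)OC)C1c1ccccc1[N+](=O)[O-]`, gives 8 nM
- compound 3, `C#CCCOC(=O)C1=C(C)NC(C)=C(C(=O)OC)C1c1cccc([N+](=O)[O-])c1`, gives 31 nM

All three share a core carrying two ester groups and a nitrophenyl ring, and they differ in the ester chains and in where the nitro group sits. Compound 3 carries the highest number of the three, yet its gap to compound 1 is within the usual scatter of repeated measurements, so the two cannot be told apart; only the gap to compound 2 lies beyond that scatter, and there compound 3 is the weaker inhibitor.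

The next compound, compound 4, `COC(=O)C1=C(C)NC(C)=C(C(=O)OCc2ccco2)C1c1cccc([N+](=O)[O-])c1`, keeps everything of compound 3 except one ester chain, where the change is furan-2-yl in place of propargyl on a saturated chain carbon bound to an oxygen next to a carbonyl group.

Among the measured compounds shown here, no measured pair shows what such an exchange does here. Ester chains of several kinds already give numbers of similar size, so the step is expected to be small, a 1.2-fold lower number from compound 3 to compound 4 (0.09 log units; within the scatter), with no clear direction beyond the scatter. Compound 4 is therefore estimated at 25 nM, most likely between 8 nM and 80 nM.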

Compound 4, half-maximal inhibitory concentration: 20 nM
The estimate for compound 4 lay 1.3-fold (0.10 log units) above the measured number, and the stated range covers the measured number.
By their numbers in this assay, from the lowest: compound 2; then compounds 1, 4 and 3 (each within the scatter of the next).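

In this assay the exchange of propargyl for furan-2-yl on a saturated chain carbon bound to an oxygen next to a carbonyl group gives a 1.6-fold lower number from compound 3 to compound 4 (0.19 log units; within the scatter) and so stays within the usual scatter. Among the compounds shown here, this is the first measured pair that differs in one place, and it shows that this ester chain can carry a five-membered aromatic ring with one hetero atom instead of a triple bond while the two numbers remain indistinguishable. Nothing available here explains why the exchange has so little visible effect.

On these data alone, whether an amine, a carboxylic acid or a longer chain at this place would move the number beyond the scatter remains open. As far as these compounds go, it is also open whether the same exchange would behave alike on the other ester chain of the shared core.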